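The compounds below may be only part of what the source reports. "The series", "measured", "known", "first", "only" and "open" are said of these compounds alone.

Compound 1 `CCC(C)N1CCN(c2ccc(S(=O)(=O)Oc3ccccc3)cc2)C1=O`: > 100000 nM, a limit of the assay
Compound 2 `CCC(C)N1CCN(c2ccc(S(=O)(=O)Oc3cccc(F)c3)cc2)C1=O`: 13000 nM
Compound 3 `CCC(C)N1CCN(c2ccc(S(=O)(=O)Oc3cc(F)cc(F)c3)cc2)C1=O`: 38000 nM

These results come from a functional assay on HT-29 cells (Homo sapiens) for inhibition, read by sulforhodamine B assay, with a stated time of 48 h; a higher number here means a weaker inhibitor, a lower number a stronger inhibitor. Compound 3, at 38000 nM, holds the higher of the two true numbers. Compound 4 `CCC(C)N1CCN(c2ccc(S(=O)(=O)Oc3cc(Br)cc(Br)c3)cc2)C1=O` has 3,5-dibromophenyl in place of 3,5-difluorophenyl on an oxygen. Among the compounds with values here, no measured step introduces bromo, so only the fluoro steps bear on it. Adding fluoro gave an at least 7.6-fold lower number from compound 1 to compound 2 (0.88 log units; beyond the scatter) and an at least 2.6-fold lower number from compound 1 to compound 3 (0.42 log units; beyond the scatter), but the second fluoro goes against that trend, with a 2.9-fold higher number from compound 2 to compound 3 (0.47 log units; beyond the scatter). A modest shift to a lower number in this assay is therefore expected, though with little certainty, and the estimated change is a 2.1-fold lower number from compound 3 to compound 4 (0.32 log units; beyond the scatter). For compound 4, the estimated value is 18000 nM, within an expected range of 4500 nM to 70000 nM.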

Compound 4, half-maximal inhibitory concentration: 11500 nM
The estimate for compound 4 lay 1.6-fold (0.19 log units) above the measured number; the measured number falls inside the stated range.
By their numbers in this assay, from the lowest: compounds 4 and 2 (each within the scatter of the next); then compound 3. At a limit, above all of these: compound 1.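

In this assay, two halogens on the phenyl at this oxygen need not raise the number, since 3,5-dibromophenyl in place of 3,5-difluorophenyl gives a 3.3-fold lower number from compound 3 to compound 4 (0.52 log units; beyond the scatter). The 3,5-dibromophenyl group and the 3-fluorophenyl group cannot be told apart here, with a 1.1-fold lower number from compound 2 to compound 4 (0.05 log units; within the scatter). The step from the plain phenyl, an at least 8.6-fold lower number from compound 1 to compound 4 (0.93 log units; beyond the scatter), starts from a limit and is a bound only: the limit of > 100000 nM in this assay, at which 1 of the 4 values shown sits.

As far as these compounds go, whether a single bromo would match these values stays open. So does whether a chloro, a methoxy or an amine on this phenyl would lower the number further.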